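A few compounds are considered here, and "the series" means these few. Any claim that something is new, unique, unknown or untested is made for them only; others in the source may bear on it.

Measured in a functional assay on SMMC-7721 cells (Homo sapiens) for inhibition, read by CCK-8 assay, with a stated time of 72 h, tested at 8 uM; a higher number here means more inhibition of growth at the concentration tested, a lower number less inhibition of growth:

- compound 1 `Cc1cc(C)cc(SCc2ccc(/C=C/C(=O)Nc3ccccc3N)cc2)c1` gives 7.13%
- compound 2 `Nc1ccccc1NC(=O)c1ccc(CSc2nccc(C(F)(F)F)n2)cc1` gives 80.6%
- compound 3 `CC(C)(C)c1ccc(SCc2ccc(C(=O)Nc3ccccc3N)cc2)cc1` gives 46.1%

Compound 1 stands lowest of the three, and both compound 3 and compound 2 lie above it by more than the usual scatter of repeat measurements. Its growth inhibition at the tested concentration is therefore weak, which leaves room for a change to show upward.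

The next compound to be tested is compound 4 `Nc1ccccc1NC(=O)/C=C/c1ccc(CSCCc2ccccc2)cc1`. It carries the same atoms as compound 1, joined differently, with phenethyl in place of 3,5-dimethylphenyl on a sulfur. The rest of the molecule stays as it is.

Going by the values given here, no two measured compounds differ in one place only, so the data give no direct measure of what such a swap does. Compound 2 and compound 3 also differ from compound 1 elsewhere, so their higher values say little about this change. The starting point is therefore compound 1 itself, at 7.13%, and the expectation is a small rise in this assay that may well stay within the scatter.

The expected change is a number 6.9 percentage points higher from compound 1 to compound 4 (within the scatter).

For compound 4 the estimated value is 14%, with an expected range from 3% to 38%.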

Compound 4, percent growth inhibition at one concentration: 15.8%
The estimate for compound 4 lay 1.8 percentage points below the measured number, within the range that was stated.
By their numbers in this assay, from the lowest: compounds 1 and 4 (each within the scatter of the next); then compound 3; then compound 2.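

In this assay, putting phenethyl in place of 3,5-dimethylphenyl on a sulfur gives a number 8.7 percentage points higher from compound 1 to compound 4 (within the scatter), so the two compounds cannot be told apart in this measurement. Going by these compounds alone, this is the first direct comparison at this position, and it covers two groups with the same count of heavy atoms and the same aromatic ring of carbon only, with the ring placed directly on the sulfur in one and carried on the phenethyl chain in the other. On this shared core, that difference in how the ring is attached gives no readable effect on growth inhibition, and no available measurement offers an explanation for this result.

As far as these compounds go, it remains open whether a group of a different kind on the sulfur, such as an amine, a carboxylic acid or a chain longer than phenethyl, would move the number beyond the scatter on this core. From the compounds shown here alone, the steps to compound 2 and compound 3 cannot be read as effects of one change, so it also remains open whether the same swap would give a similar result on either of their cores.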